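Changing one ring on the shared core alters cell tolerance

This account rests on a few compounds, and the source may have more. Where it says the series, first, only, none or still open, it means among the compounds named here.

- compound 1 `Cc1cc(-c2cncnc2)cc(C)c1Nc1ccnc(Nc2ccc(C#N)cc2)n1`: 6800 nM
- compound 2 `Cc1cc(-c2cccc3cc[nH]c23)cc(C)c1Nc1ccnc(Nc2ccc(C#N)cc2)n1`: 1000 nM
- compound 3 `Cc1ccc(-c2cc(C)c(Nc3ccnc(Nc4ccc(C#N)cc4)n3)c(C)c2)s1`: 28000 nM

In a toxicity assay on MT4 cells (Homo sapiens) for cytotoxicity, read by MTT assay, with a stated time of 5 days (a lower number here means that less compound is tolerated, a higher number that more compound is tolerated), compound 3 stands highest of the three at 28000 nM. Compound 4 `Cc1cc(-c2ccnc(F)c2)cc(C)c1Nc1ccnc(Nc2ccc(C#N)cc2)n1` carries 2-fluoropyridin-4-yl in place of 5-methylthiophen-2-yl on an aromatic carbon. Two measured steps at this same place bear on the change: a 4.1-fold higher number from compound 1 to compound 3 (0.61 log units; beyond the scatter) and a 28-fold higher number from compound 2 to compound 3 (1.45 log units; beyond the scatter). Each ends on the 5-methylthiophen-2-yl group with a higher number, so leaving that group is expected to lower the number. Compound 1, with its pyrimidin-5-yl group, is taken as the closer guide, which points to a modest step. The estimated change is a 3.5-fold lower number from compound 3 to compound 4 (0.54 log units; beyond the scatter). For compound 4 the expected value is 8000 nM, with an estimated range of 2500 nM to 25000 nM.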

Compound 4, half-maximal cytotoxic concentration: 6000 nM
The estimate for compound 4 lay 1.3-fold (0.12 log units) above the measured number; the range from low to high includes it.
By their numbers in this assay, from the lowest: compound 2; then compounds 4 and 1 (each within the scatter of the next); then compound 3.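

In this assay there is a 4.7-fold lower number from compound 3 to compound 4 (0.67 log units; beyond the scatter) and so the high number of compound 3 is not matched by a second six-membered aromatic group. With a 1.1-fold lower number from compound 1 to compound 4 (0.05 log units; within the scatter) within the scatter, 2-fluoropyridin-4-yl and pyrimidin-5-yl cannot be told apart at this position, while a 6.0-fold higher number from compound 2 to compound 4 (0.78 log units; beyond the scatter) leaves 1H-indol-7-yl with the lowest number of the set. Nothing measured here accounts for these differences. Still open, on these data alone, is whether a plain pyridin-4-yl group would match compound 4, and how an amine or a carboxylic acid at this position would fare.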